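Bromine removal on the indolyl cyclic amidine series

A few compounds are considered here, and "the series" means these few. Any claim that something is new, unique, unknown or untested is made for them only; others in the source may bear on it.

Measured compounds:
compound 1, `O=C1N[C@@H](c2c[nH]c3ccccc23)CN=C1c1c[nH]c2ccccc12`: 8.3 ug/mL
compound 2, `O=C1NC[C@@H](c2c[nH]c3cc(Br)ccc23)N=C1c1c[nH]c2ccccc12`: 3.71 ug/mL

Both compounds share one core and were run in an ADME assay on A549 cells (Homo sapiens) for cytotoxicity; a lower number here means that less compound is needed, a higher number that more compound is needed for the effect. Going by the values given here, compound 2 holds the lower of the two numbers; the gap to compound 1, the only other measured compound, lies beyond the usual scatter, so compound 2 needs less material for the half-maximal effect than compound 1 does. Among the compounds with values here, no single-point step between the two measured compounds is available, so only their two values are compared here.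

Compound 3, `O=C1NC[C@@H](c2c[nH]c3ccccc23)N=C1c1c[nH]c2ccccc12`, is the next compound to be measured in this assay. It differs from compound 2 by hydrogen in place of bromo on an aromatic carbon. Within the data shown here, with no measured step to lean on, the direction of this change is open; a modest rise in the number, of a size that may not exceed the scatter, is the working expectation. Compound 3 is therefore estimated at 6 ug/mL, with a range of 3 ug/mL to 12 ug/mL. This estimate means an expected step of a 1.6-fold higher number from compound 2 to compound 3 (0.21 log units; within the scatter).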

Compound 3, concentration for half-maximal effect: 11.7 ug/mL
Beside the measured number, compound 3's estimate is 2.0-fold (0.29 log units) below it; the measured number falls inside the stated range.
By their numbers in this assay, from the lowest: compound 2; then compounds 1 and 3 (each within the scatter of the next).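

In this assay, going by these compounds alone, the change from bromo to hydrogen gives a 3.2-fold higher number from compound 2 to compound 3 (0.50 log units; beyond the scatter) and is the first single-place step, so the substituent on this aromatic carbon, meta to a fused ring and para to a fused ring, bears on the number. With bromo at this carbon less compound is needed for the half-maximal effect than with hydrogen, although this rests on a single matched pair on the shared core and sets no trend for the series. Nothing available explains the size or direction of this step.

Still open, from the compounds shown here alone, is whether the step is particular to bromo or would also appear with another halogen such as chloro or fluoro, or with a different kind of group such as methoxy, an amine or a carboxylic acid on the same aromatic carbon. Also open, going by these compounds, is whether bromo on another aromatic carbon of the shared core would give a step of similar size, and whether the same change behaves alike on the core of compound 1.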